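This account rests on a few compounds, and the source may have more. Where it says the series, first, only, none or still open, it means among the compounds named here.

Compound 1 `NCCn1ncc2c(NCc3ccccc3[N+](=O)[O-])cc(C(F)(F)F)cc21`: 29% in an assay for inhibition of Tryptophan 2,3-dioxygenase (Homo sapiens), with stated times of 10 min and 60 min, tested at 100 uM; a lower number here means a weaker effect, a higher number a stronger effect of the compound at the concentration tested
Compound 2 `O=[N+]([O-])c1ccccc1CNc1cc(C(F)(F)F)cc2[nH]ncc12`: 95% in this assay
Compound 3 `O=[N+]([O-])c1ccc(Cl)cc1CNc1cc(C(F)(F)F)cc2[nH]ncc12`: 88% in this assay

Among these three, compound 2 gives the highest number. Compound 3 comes closest, and the step of a number 7 percentage points lower from compound 2 to compound 3 (within the scatter) lies within the scatter, so the two cannot be told apart on these figures. Compound 1 sits far off, as the step of a number 66 percentage points higher from compound 1 to compound 2 (beyond the scatter) shows.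

Compound 4 `O=[N+]([O-])c1ccccc1CNc1cc(Br)cc2[nH]ncc12` has not yet been measured. It differs from compound 2 in one place: bromo in place of trifluoromethyl on an aromatic carbon. Neither measured step touches this group. The step of a number 66 percentage points higher from compound 1 to compound 2 (beyond the scatter) concerns the aromatic nitrogen, which is unchanged here. Going by the values given here, the step of a number 7 percentage points lower from compound 2 to compound 3 (within the scatter) is the only one that swaps a group on an aromatic carbon, and it stayed within the scatter, but it sits on the other ring and swaps hydrogen for chloro, not trifluoromethyl for bromo. Among the compounds with values here, the expectation therefore rests on little: the rest of the molecule is kept, and the one swap on an aromatic carbon seen so far did not move the number. A step within the scatter, or at most a modest fall, is expected in this assay. The expected step is a number 10 percentage points lower from compound 2 to compound 4 (within the scatter). Compound 4 is estimated at 85%, with a range from 60% to 98%.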

Compound 4, a percentage reported as inhibition, at one concentration (the size of the read-out at that concentration, not a potency): 64%
Beside the measured number, compound 4's estimate is 21 percentage points above it; the range from low to high includes it.
By their numbers in this assay, from the lowest: compound 1; then compound 4; then compounds 3 and 2 (each within the scatter of the next).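

The step of a number 31 percentage points lower from compound 2 to compound 4 (beyond the scatter) shows that in this assay this position is sensitive to the group it carries: bromo, a single heavy atom, does not simply stand in for trifluoromethyl, which has four. Going by these compounds alone, the earlier change on an aromatic carbon, a number 7 percentage points lower from compound 2 to compound 3 (within the scatter), swapped hydrogen for chloro at a different place and could not be told apart from no change, so this is the first such swap to move the number clearly. The compounds shown offer no measurement that explains this gap between trifluoromethyl and bromo.

Going by these compounds, with only these two groups compared at this position, it remains open whether trifluoromethyl is unusually favourable or bromo unusually poor, and a nitrile or a methoxy group there could help to separate those two readings. It is also unknown whether the same swap would have a similar effect in a compound carrying the chloro of compound 3 or the 2-aminoethyl group of compound 1, since each comparison here changes only one place.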